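The source may report more compounds than this note shows. Statements on the series, on what has been measured and on what is new or still open speak of the compounds shown alone.

Working notes on the series. Compound 1 `O=C(NNC(=O)c1ccccc1Cl)c1cccc(NS(=O)(=O)c2cnc(O)nc2O)c1`, compound 2 `O=C(NNC(=O)c1cccc(NS(=O)(=O)c2cnc(O)nc2O)c1)c1cccc(Cl)c1` and compound 3 `O=C(NNC(=O)c1ccccc1NS(=O)(=O)c1cnc(O)nc1O)c1ccccc1Cl` have been measured; compound 4 `O=C(NNC(=O)c1ccccc1NS(=O)(=O)c1cnc(O)nc1O)c1cccc(Cl)c1` has not. In a functional assay on A549 cells (Homo sapiens) for antiproliferative activity, read by MTT assay, with a stated time of 24 h (a higher number here means a weaker inhibitor, a lower number a stronger inhibitor), compound 1 gives 3740 nM. In this assay compound 2 gives 6000 nM. In this assay compound 3 gives 5290 nM. Compound 3 lies within the scatter of compound 2 and also within the scatter of compound 1, so no ranking of the three is drawn. The difference between the core of compound 1 and the core of compound 3 is not broken down here.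

The change from compound 1 to compound 2 is 3-chlorophenyl in place of 2-chlorophenyl on a carbonyl carbon. In this assay it made a 1.6-fold higher number from compound 1 to compound 2 (0.21 log units; within the scatter), which is not a step that can be told from repeat measurement. The change from compound 3 to compound 4 is 3-chlorophenyl in place of 2-chlorophenyl on a carbonyl carbon. Its place reads the same word for word as before, so this is the same change, made on a different core.

The step expected in this assay is a 1.4-fold higher number from compound 3 to compound 4 (0.15 log units; within the scatter), set beside the measured 1.6-fold higher number from compound 1 to compound 2 (0.21 log units; within the scatter). This rests on compound 1 and compound 2, where the same change gave a 1.6-fold higher number from compound 1 to compound 2 (0.21 log units; within the scatter), and on the scatter being wide enough that the sign of such a step is uncertain. Compound 4 is accordingly expected to give about 7500 nM in this assay. For compound 4 the estimated range runs from 3500 nM to 16000 nM.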

Compound 4, half-maximal inhibitory concentration: 1260 nM
Compound 4: middle estimate off by 6.0-fold (0.77 log units), on the high side; the whole stated range lies above it.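

In this assay, 3-chlorophenyl in place of 2-chlorophenyl on a carbonyl carbon gave a 4.2-fold lower number from compound 3 to compound 4 (0.62 log units; beyond the scatter), so on the core of compound 3 this change can be told from repeat measurement. The result rests on a single pair, but it shows that the change does not carry over at a fixed size from the core of compound 1 to the core of compound 3, as the two steps differ by more than repeat measurement would explain: the same change on two cores in this assay, a 1.6-fold higher number (0.21 log units; within the scatter) from compound 1 to compound 2 and a 4.2-fold lower number (0.62 log units; beyond the scatter) from compound 3 to compound 4, 6.7-fold (0.83 log units) apart, beyond the scatter of two such steps

This does not show why the outcome depends on the core, nor does it give a rule for any further core, and the step on the core of compound 1 remains too small to fix even its direction, so the contrast is between one step that can be read clearly and one that cannot.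

The compounds shown leave open whether the same dependence on the core appears when the chlorine is replaced by a methoxy group or an amine, or when the ring carries no substituent at all. They also leave open whether the step on the core of compound 3 holds in cell lines other than A549.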